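The source may report more compounds than this note shows. Statements on the series, on what has been measured and on what is new or still open speak of the compounds shown alone.

Measured compounds:
Compound 1 `COc1ncc(-c2ccc3ncnc(Nc4ccc(OCCO)c(F)c4)c3c2)cc1NS(=O)(=O)c1ccc(F)cc1F` gives 4820 nM in a functional assay on MCF7 cells (Homo sapiens) for antiproliferative activity, read by sulforhodamine B assay, with a stated time of 72 h; on this read-out higher numbers stand for weaker inhibition and lower numbers for stronger inhibition.
Compound 2 `COc1ncc(-c2ccc3ncnc(Nc4cnn(CC(=O)O)c4)c3c2)cc1NS(=O)(=O)c1ccc(F)cc1F` gives 700 nM in this assay.
Compound 3 `COc1ncc(-c2ccc3ncnc(Nc4ccc(OCCO)c(Cl)c4)c3c2)cc1NS(=O)(=O)c1ccc(F)cc1F` gives 3740 nM in this assay.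

Among these three numbers compound 3 stands second highest. Its nearest neighbour is reached by a 1.3-fold lower number from compound 1 to compound 3 (0.11 log units; within the scatter), a step that the usual scatter covers, so the two are best read as the same. Its furthest neighbour is reached by a 5.3-fold higher number from compound 2 to compound 3 (0.73 log units; beyond the scatter), a step that clearly lies beyond the scatter.

Compound 4 `COc1ncc(-c2ccc3ncnc(Nc4cnn(CCCO)c4)c3c2)cc1NS(=O)(=O)c1ccc(F)cc1F` is the next compound, not yet measured in this assay. It differs from compound 3 in one place: 1-(3-hydroxypropyl)-1H-pyrazol-4-yl in place of 3-chloro-4-(2-hydroxyethoxy)phenyl on a nitrogen on an aromatic ring.

Among the compounds with values here, two measured steps bear on this change. Both a 6.9-fold lower number from compound 1 to compound 2 (0.84 log units; beyond the scatter) and a 5.3-fold higher number from compound 2 to compound 3 (0.73 log units; beyond the scatter) swap the substituted phenyl ring on that nitrogen against a pyrazole, and in each case the pyrazole side carried the lower number. Within the data shown here, compound 4 carries a pyrazole as well, but with 3-hydroxypropyl rather than carboxymethyl on its ring nitrogen, and no measured pair covers that difference. A lower number in this assay is therefore expected for compound 4, with a wide range to allow for the untested substituent. The expected step is a 3.4-fold lower number from compound 3 to compound 4 (0.53 log units; beyond the scatter). Compound 4 is estimated at 1100 nM, between 350 nM and 4000 nM.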

Compound 4, half-maximal inhibitory concentration: 1310 nM
The estimate for compound 4 lay 1.2-fold (0.08 log units) below the measured number, and the stated range covers the measured number.
By their numbers in this assay, from the lowest: compounds 2 and 4 (each within the scatter of the next); then compounds 3 and 1 (each within the scatter of the next).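

In this assay, the pyrazole side keeps the lower number without the carboxymethyl group, as a 2.9-fold lower number from compound 3 to compound 4 (0.46 log units; beyond the scatter) and a 3.7-fold lower number from compound 1 to compound 4 (0.57 log units; beyond the scatter) both lie beyond the scatter, so this trend on the nitrogen no longer rests on compound 2 alone. The step within the pyrazole series, a 1.9-fold higher number from compound 2 to compound 4 (0.27 log units; within the scatter), stays within the scatter, which means that compound 2 and compound 4 are best read as the same and that the carboxy group is not required for this level of activity. Across the four compounds, each pyrazole stands below each substituted phenyl compound by a step beyond the scatter, and none goes against this, although the steps from the phenyl compounds to compound 4 change the ring and its substituents together and so do not isolate the ring itself.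

Nothing available here explains why the pyrazole compounds carry the lower numbers. On these data alone, it also remains open whether a pyrazole bearing a primary amine on a longer chain, or a simple methyl group on its ring nitrogen, would stay at this level, and whether a phenyl ring bearing a 3-hydroxypropyl chain would match it.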